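From 2-hydroxyethyl to cyclohexyl on the shared core

The compounds below may be only part of what the source reports. "The series", "measured", "known", "first", "only" and "open" are said of these compounds alone.

- compound 1 `C=CC[C@@H]1O[C@H](COCc2ccccc2)[C@@H](OCc2ccccc2)[C@H](OCc2ccccc2)[C@H]1O`: 26200 nM
- compound 2 `OCCC[C@@H]1O[C@H](COCc2ccccc2)[C@@H](OCc2ccccc2)[C@H](OCc2ccccc2)[C@H]1O`: > 50000 nM (a limit)
- compound 3 `O[C@@H]1[C@@H](OCc2ccccc2)[C@H](OCc2ccccc2)[C@@H](COCc2ccccc2)O[C@H]1CC1CCCCC1`: not yet measured

All values come from a functional assay on HeLa cells (Homo sapiens) for antiproliferative activity, read by sulforhodamine B assay (a lower number here means a stronger inhibitor of growth, a higher number a weaker inhibitor of growth), and no other test. Compound 2 sits at the limit of > 50000 nM in this assay, at which 1 of the 2 values shown sits, and so gives a limit and not a number. Compound 3 carries cyclohexyl in place of 2-hydroxyethyl on a saturated chain carbon bound to a saturated ring carbon. Only an at least 1.9-fold higher number from compound 1 to compound 2 (0.28 log units; that floor lies within the scatter) bears on this and it sets no firm size. Within the data shown here, a small move to a lower number is expected, resting on compound 1 at 26200 nM as the only number so far. The expected change is (an at least 1.6-fold lower number from compound 2 to compound 3 (0.22 log units; that floor lies within the scatter)). For compound 3 the estimate is 30000 nM with an expected range of (13000 nM to 60000 nM).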

Compound 3, concentration for 50% growth inhibition: 9500 nM
Beside the measured number, compound 3's estimate is 3.2-fold (0.50 log units) above it; measured number outside the range, below it.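

In this assay, among these compounds, cyclohexyl gives the first change at this saturated chain carbon that clearly exceeds the scatter: an at least 5.2-fold lower number from compound 2 to compound 3 (0.72 log units; beyond the scatter). The gain is not tied to the comparison with 2-hydroxyethyl alone, since replacing vinyl also shows a 2.8-fold lower number from compound 1 to compound 3 (0.44 log units; beyond the scatter). Compound 2 gives only a limit, which makes the first step a floor: the limit of > 50000 nM in this assay, at which 1 of the 3 values shown sits.

Going by these compounds, it remains open whether the ring itself matters or a longer alkyl chain would serve as well. On these data alone, how a phenyl ring or an amine would compare with cyclohexyl at this place also stays unknown.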